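Ester branching on two related cores at adenosine receptor A3

The source may report more compounds than this note shows. Statements on the series, on what has been measured and on what is new or still open speak of the compounds shown alone.

Three compounds built around two closely related cores were tested in an assay on membranes from HeLa cells for displacement of a labelled ligand from adenosine receptor A3 (Homo sapiens), read by scintillation counting, with a stated time of 180 min, tested at 1 uM; on this read-out lower numbers stand for less inhibition and higher numbers for more inhibition at the one concentration tested (going by the name of the read-out). Compound 1 `CC1=C(C(=O)OCC(C)C)C(c2cccs2)NC(=O)N1` gives 11% in this assay, and compound 2 `CC1=C(C(=O)OC(C)(C)C)C(c2cccs2)NC(=O)N1` gives 7%. The change between them is tert-butyl in place of isobutyl on an oxygen next to a carbonyl group; it made a step of a number 4 percentage points lower from compound 1 to compound 2 (within the scatter). Compound 3 `CC1=C(C(=O)OCC(C)C)C(c2ccco2)NC(=O)N1C` carries the same isobutyl ester on a different core and gives 23% in this assay, which stands highest of the three numbers, with compound 1 the nearest and compound 2 the furthest of the other two. The difference between the core of compound 3 and the core of compound 1 is not broken down here.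

Compound 4 `CC1=C(C(=O)OC(C)(C)C)C(c2ccco2)NC(=O)N1C` has not yet been measured in this assay. It differs from compound 3 by tert-butyl in place of isobutyl on an oxygen next to a carbonyl group, the same change that turned compound 1 into compound 2, made at the same place. Because that earlier change produced only a number 4 percentage points lower from compound 1 to compound 2 (within the scatter), a step within the scatter, a similarly small step is expected here. Starting from the value of compound 3, 23%, compound 4 is expected to move by about a number 4 percentage points lower from compound 3 to compound 4 (within the scatter) in this assay. The estimate for compound 4 is therefore 19%, within a range from 6% to 32%, with the wider uncertainty reflecting that the earlier step rests on a single pair on the other core.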

Compound 4, a percentage reported as inhibition, at one concentration (the size of the read-out at that concentration, not a potency): 54%
Compound 4: the middle estimate sits 35 percentage points below what was measured; measured number above the stated range.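

In this assay, tert-butyl in place of isobutyl on an oxygen next to a carbonyl group gives a number 31 percentage points higher from compound 3 to compound 4 (beyond the scatter), whereas the same change on the core of compound 1 gives a number 4 percentage points lower from compound 1 to compound 2 (within the scatter). The change therefore does not carry over as a fixed step from one core to the other in this series, and the size of the step on one core could not be read across to the other: the same change on two cores in this assay, a number 4 percentage points lower (within the scatter) from compound 1 to compound 2 and a number 31 percentage points higher (beyond the scatter) from compound 3 to compound 4, 35 percentage points apart, beyond the scatter of two such steps The two cores differ in more than one place and no pair shown separates those differences, so the result does not show which part of the core goes with the larger step, and two pairs set no rule for any further core.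

The compounds shown leave open how the isobutyl and tert-butyl esters compare on a core that carries only one of the differences between the core of compound 1 and the core of compound 3. They also leave open how other groups on that oxygen, such as a longer chain or a benzyl group, would read in this assay on either core, and what potency lies behind these readings at a single concentration.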